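The compounds below may be only part of what the source reports. "The series", "measured", "known", "first", "only" and "open" are said of these compounds alone.

Measured in a functional assay on HCT-116 cells (Homo sapiens) for antiproliferative activity, read by sulforhodamine B assay, with a stated time of 3 days, tested at 50 uM; on this read-out higher numbers stand for a stronger effect at the one concentration tested and lower numbers for a weaker effect:
Compound 1, `O=C(/C=C/c1ccc(Cl)cc1)c1ccccc1`: 100%
Compound 2, `O=C(/C=C/c1cccc([N+](=O)[O-])c1)c1ccccc1`: 99.7%
Compound 3, `COc1cccc(/C=C/C(=O)c2ccc(OCc3ccccc3)cc2)c1`: 76%

Compound 3 stands lowest of the three numbers in this assay. Its nearest neighbour is compound 2, whose number lies higher by a margin beyond the scatter; compound 1 is furthest, also higher by a margin beyond the scatter. Compounds 1 and 2 sit within the scatter of each other, so no order between them is read. Among the compounds with values here, no two measured compounds differ in one place only, so no measured step is at hand to calibrate the next change.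

Compound 4, `O=C(/C=C/c1ccccc1)c1ccc(OCc2ccccc2)cc1`, is not yet measured. It differs from compound 3 in one place: hydrogen in place of methoxy on an aromatic carbon. The methoxy leaves an aromatic carbon of a six-membered aromatic ring of carbon only, meta to a large group, and hydrogen enters in its stead; cut one bond further out, the change reads 3-methoxyphenyl to phenyl. Nothing in the measured set isolates this methoxy, since compounds 1 and 2 carry their substituents on the other ring, and compound 3 alone carries the large group.

The expected step of a number 4 percentage points lower from compound 3 to compound 4 (within the scatter) is therefore one within the scatter, direction left open. Compound 4 is expected to give about 72% in this assay, with a range from 45% to 95%.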

Compound 4, a percentage reported as inhibition, at one concentration (the size of the read-out at that concentration, not a potency): 33.8%
Compound 4: the middle estimate sits 38.2 percentage points above what was measured; measured number outside the range, below it.
By their numbers in this assay, from the lowest: compound 4; then compound 3; then compounds 2 and 1 (each within the scatter of the next).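

In this assay the change from 3-methoxyphenyl to phenyl comes with a large step (a number 42.2 percentage points lower from compound 3 to compound 4 (beyond the scatter)), so the aromatic carbon meta to a large group is a position where the series responds strongly to a single change. Within the data shown here, this is the first measured pair that differs in one place only, and it gives a size to the loss of the methoxy with everything else in the structure held fixed, which the earlier compounds could not give. Nothing measured here explains the step, so it stands as an observation on this one pair.

From the compounds shown here alone, whether the step is specific to methoxy remains open: a hydroxyl, an ethoxy, a fluorine or an amine on the same aromatic carbon would show whether other groups keep the higher read-out of compound 3 or fall toward that of compound 4. Among these compounds, it is also open whether the step holds without the large group, and a single concentration gives no potency for either compound.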